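The source may report more compounds than this note shows. Statements on the series, on what has been measured and on what is new or still open speak of the compounds shown alone.

Within the data shown here, compound 1 `CCCn1c(=O)c2nc(C(C)(C)CCC)[nH]c2n(CCC)c1=O` is the only member of this pair of measured compounds with a numerical result: in an assay on cell membranes for binding affinity to adenosine receptor A1 (Cavia porcellus), read by radioligand binding (on this read-out higher numbers stand for weaker inhibition and lower numbers for stronger inhibition), compound 1 gives 25 nM. Compound 2 `CCCn1c(=O)c2nc(-c3cc4ccccc4s3)[nH]c2n(CCC)c1=O` reaches only a limit of this assay, > 100000 nM, as recorded in the limit of > 100000 nM in this assay, at which 1 of the 2 values shown sits. Compound 3 `CCCn1c(=O)c2nc(C(O)(CC)CC)[nH]c2n(CCC)c1=O` differs from compound 1 in one place: 1-ethyl-1-hydroxypropyl in place of 1,1-dimethylbutyl on an aromatic carbon. Among the measured compounds shown here, with no measured step of this kind to lean on, a modest loss of affinity in this assay is expected, and the step from compound 1 to compound 3 is estimated at a 3.2-fold higher number from compound 1 to compound 3 (0.51 log units; beyond the scatter). Compound 3 is therefore expected to give about 80 nM, within 20 nM to 400 nM.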

Compound 3, inhibition constant: 170 nM
Compound 3: the middle estimate sits 2.1-fold (0.33 log units) below what was measured, within the range that was stated.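

Replacing 1,1-dimethylbutyl with 1-ethyl-1-hydroxypropyl, two groups with the same heavy-atom count, gives a 6.8-fold higher number from compound 1 to compound 3 (0.83 log units; beyond the scatter) in this assay as a modest loss of affinity. A chain carrying a hydroxyl on this aromatic carbon therefore still allows binding that can be given as a number. No measurement shown bears on why affinity falls with this change. The compounds shown leave open whether the hydroxyl or the rearranged carbon chain accounts for the step, and how an amine or a carboxylic acid would fare at this position.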